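Swapping the triazole arm for a hydroxypiperidine chain

The source may report more compounds than this note shows. Statements on the series, on what has been measured and on what is new or still open speak of the compounds shown alone.

The shared core of compound 1 `O=C1c2c[n+]([O-])c3ccccc3c2C(=O)c2c1c1ccccc1n2Cc1cn(C[C@@H](O)CO)nn1` carries an arm on one aromatic nitrogen, and the three compounds measured differ only within that arm. In a toxicity assay on HEK-293T cells (Homo sapiens) for cytotoxicity, read by MTT assay, with a stated time of 72 h (on this read-out higher numbers stand for weaker inhibition and lower numbers for stronger inhibition), compound 1 gives 2030 nM, the highest of the three numbers. Compound 2 `O=C1c2c[n+]([O-])c3ccccc3c2C(=O)c2c1c1ccccc1n2Cc1cn([C@@H]2C[C@H](O)[C@@H](CO)O2)nn1` gives 820 nM, and compound 3 `CC1(C)OC[C@H](Cn2cc(Cn3c4c(c5ccccc53)C(=O)c3c[n+]([O-])c5ccccc5c3C4=O)nn2)O1` gives 100 nM. The measured steps run a 2.5-fold lower number from compound 1 to compound 2 (0.39 log units; beyond the scatter) and a 20-fold lower number from compound 1 to compound 3 (1.31 log units; beyond the scatter), so each change within this arm has moved the read-out clearly, in both cases towards stronger inhibition. Compound 4 `O=C1c2c[n+]([O-])c3ccccc3c2C(=O)c2c1c1ccccc1n2CCCN1CCC(O)CC1` has not yet been measured; it differs from compound 1 as follows: 2-(4-hydroxypiperidin-1-yl)ethyl in place of 1-(2,3-dihydroxypropyl)-1H-1,2,3-triazol-4-yl on a saturated chain carbon bound to an aromatic nitrogen. Within the data shown here, no measured step removes the triazole ring itself, so the earlier steps bear on compound 4 only in showing that this arm matters to the read-out. For compound 4 the estimated step is a 2.5-fold lower number from compound 1 to compound 4 (0.40 log units; beyond the scatter), leaning towards a lower number with wide uncertainty. Compound 4 is therefore expected to give about 800 nM, within a range from 150 nM to 4000 nM.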

Compound 4, half-maximal inhibitory concentration: 170 nM
Compound 4: middle estimate off by 4.7-fold (0.67 log units), on the high side; the range from low to high includes it.
By their numbers in this assay, from the lowest: compounds 3 and 4 (each within the scatter of the next); then compound 2; then compound 1.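

Compound 4 shows that the triazole ring is not needed for a low number at this position: replacing the whole arm of compound 1 with a 3-(4-hydroxypiperidin-1-yl)propyl chain gives a 12-fold lower number from compound 1 to compound 4 (1.08 log units; beyond the scatter) in this assay. Among these compounds, the earlier compounds all kept the triazole and varied only what hung from it, so this is the first sign that a chain without that ring can also reach the low end of the series. No measurement shown here accounts for this step.

Going by these compounds, because the ring, the chain and the hydroxypiperidine all change together, the share of each in the step remains open. A plain piperidine or a morpholine on the same propyl chain, or the same hydroxypiperidine on a shorter chain, would begin to separate them.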